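Phenyl for propyl on a triple-bonded carbon

This account rests on a few compounds, and the source may have more. Where it says the series, first, only, none or still open, it means among the compounds named here.

Compound 1 `O=c1[nH]c(=O)n([C@H]2C[C@H](O)[C@@H](CO)O2)cc1[N+](=O)[O-]` gives 130 nM as a measured value
Compound 2 `CCCC#Cc1cn([C@H]2C[C@H](O)[C@@H](CO)O2)c(=O)[nH]c1=O` gives > 200000 nM as a limit and not a number

Compound 2 reaches only a limit in an ADME assay on L1210/0 cells (Mus musculus) for cytotoxicity, with a stated time of 48 h (on this read-out lower numbers stand for stronger inhibition and higher numbers for weaker inhibition), and has no number there. Compound 3 `O=c1[nH]c(=O)n([C@H]2C[C@H](O)[C@@H](CO)O2)cc1C#Cc1ccccc1` keeps the shared core and the triple bond of compound 2. The change is phenyl in place of propyl on a triple-bonded carbon and it lies on a triple-bonded carbon, where phenyl takes the place of propyl. Among the measured compounds shown here, no measured step touches this place directly. For the measured compounds named here, the only step measured is an at least 1500-fold higher number from compound 1 to compound 2 (3.18 log units; beyond the scatter) and it is large and beyond the scatter, but it replaces nitro rather than anything on the triple bond. Taking an at least 1500-fold higher number from compound 1 to compound 2 (3.18 log units; beyond the scatter) as the only guide, compound 3 is expected to stay close to compound 2 in this assay with no step beyond the scatter in either direction, and it may also read only as a limit. The expected step is an at least 1.3-fold lower number from compound 2 to compound 3 (0.12 log units; that floor lies within the scatter) and no larger. For compound 3 the estimate is 150000 nM with an expected range of 20000 nM to 400000 nM in this read-out.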

Compound 3, half-maximal inhibitory concentration: > 200000 nM
Compound 3 gave a limit, no number; the forecaster's own chance of this, stated with the estimate: 60%; at least 1.3-fold (0.12 log units) between middle value and limit.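

Replacing nitro with 2-phenylethynyl on an aromatic carbon gives an at least 1500-fold higher number from compound 1 to compound 3 (3.18 log units; beyond the scatter) in this assay, so the large step first seen with pent-1-yn-1-yl also appears with a group carrying a six-membered aromatic ring in place of propyl. The step between compound 2 and compound 3 cannot be read, as both values are limits and neither is a number, so nothing orders propyl and phenyl on the triple-bonded carbon. The two compounds with a triple bond therefore share one reading, and only the nitro compound gives a number: the limit of > 200000 nM in this assay, at which 2 of the 3 values shown sit.

Going by these compounds, it stays open whether any group on the triple-bonded carbon brings a measured value back into range. An amine or a carboxylic acid there, or a chain shorter than propyl, would test this in this assay.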